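The source may hold more compounds than are shown below. What is called first, only, known or untested is meant among the compounds shown, and "the series" means these compounds.

Of the compounds shown here, three built on one shared core have been tested in a functional assay on HL-60 cells (Homo sapiens) for cytotoxicity, read by MTT assay, with a stated time of 72 h; on this read-out higher numbers stand for weaker inhibition and lower numbers for stronger inhibition. Compound 1 `Cc1nnc2nnc(N3CCCC3)nn12` carries a methyl group on the core together with a pyrrolidine ring, and in this assay compound 1 gives 29700 nM. Compound 2 `Clc1ccc(-c2nnc3nnc(N4CCCC4)nn23)c(Cl)c1` carries a dichlorophenyl group in place of the methyl, and in this assay compound 2 gives 8650 nM. Compound 3 `COc1ccc(-c2nnc3nnc(N4CCCCC4)n3n2)cc1` carries a methoxyphenyl group and a piperidine ring instead of the pyrrolidine, and in this assay compound 3 gives 12900 nM. Compound 1 thus stands at the highest number of the three and is the weakest inhibitor of this set: the gap down to compound 3 is beyond the scatter, and the gap down to compound 2 is wider still. Within the data shown here, compounds 2 and 3 each differ from compound 1 in more than one place, and no pair of measured compounds differing in a single place is available to calibrate a step.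

Compound 4 `CCc1nnc2nnc(N3CCCC3)nn12` differs from compound 1 by methyl in place of hydrogen on a saturated chain carbon bound to an aromatic carbon; cut one bond further out, the same difference reads methyl to ethyl. Among the measured compounds shown here, with no comparable step measured, the expectation for compound 4 is a step from compound 1 of a 1.4-fold lower number from compound 1 to compound 4 (0.13 log units; within the scatter), most likely nothing beyond the scatter. Compound 4 is therefore estimated at 22000 nM, within a range of 9000 nM to 55000 nM.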

Compound 4, half-maximal inhibitory concentration: 47000 nM
For compound 4 the middle estimate is 2.1-fold (0.33 log units) below the measured one; the range from low to high includes it.
By their numbers in this assay, from the lowest: compounds 2 and 3 (each within the scatter of the next); then compounds 1 and 4 (each within the scatter of the next).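

Going from methyl to ethyl on the core gives the first comparison in this set between two compounds that differ in only one place, and in this assay the change amounts to a 1.6-fold higher number from compound 1 to compound 4 (0.20 log units; within the scatter) and stays inside the normal spread of repeated measurements. Adding this one carbon to the saturated chain therefore has no effect that can be read at this position, so compound 1 and compound 4 count as equal here, and neither can be ranked above the other. No measurement at hand offers an explanation for this result.

As far as these compounds go, a step of a single carbon says little about how much this position tolerates, so it remains open whether a longer chain such as butyl, or a polar group such as an amine or a carboxylic acid at the end of the chain, would shift the number beyond the scatter. From the compounds shown here alone, it is equally open how a morpholine in place of the pyrrolidine would behave with the methyl or ethyl group kept unchanged.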